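Replacing 1-benzofuran-2-yl with iodo

This account rests on a few compounds, and the source may have more. Where it says the series, first, only, none or still open, it means among the compounds named here.

Compound 1 `CNc1ncnc2c1c(-c1ccsc1)cn2[C@@H]1O[C@H](CO)[C@@H](O)[C@H]1O`: > 20000 nM
Compound 2 `CNc1ncnc2c1c(-c1cc3ccccc3o1)cn2[C@@H]1O[C@H](CO)[C@@H](O)[C@H]1O`: > 20000 nM

In a functional assay on HCT-116 cells (Homo sapiens), read by MTT assay, with a stated time of 72 h (a lower number here means a stronger inhibitor, a higher number a weaker inhibitor), compound 2 gives > 20000 nM, which is a limit and not a number. Compound 1 gives > 20000 nM, which is also a limit. All the data so far therefore amount to the limit of > 20000 nM in this assay, at which 2 of the 2 values shown sit. Going by the values given here, the only measured step is a step that the two limits leave unreadable from compound 1 to compound 2. Compound 3 `CNc1ncnc2c1c(I)cn2[C@@H]1O[C@H](CO)[C@@H](O)[C@H]1O` has iodo in place of 1-benzofuran-2-yl on an aromatic carbon. Among the compounds with values here, no measured step has a readable size, so this expectation is tentative. Both measured compounds carry a ring at this place and compound 3 carries none, so a gain in strength is expected, as an at least 2.5-fold lower number from compound 2 to compound 3 (0.39 log units; beyond the scatter). For compound 3 the estimate is 8000 nM, with an expected range of 1000 nM to 20000 nM.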

Compound 3, half-maximal inhibitory concentration: > 100000 nM
Compound 3: no number, only a limit; the forecaster's own chance of this, stated with the estimate: 45%; middle value at least 12-fold (1.09 log units) from the limit.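

Going by these compounds alone, compound 1, compound 2 and compound 3 all give limits, not numbers, in this assay: no step between them can be read. The compounds shown leave open how strongly any of them actually inhibits.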